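The compounds below may be only part of what the source reports. "The series", "measured", "known", "first", "only" and "open" are said of these compounds alone.

Measured so far in an assay on membranes from Jurkat cells for displacement of a labelled ligand from Sigma non-opioid intracellular receptor 1 (Homo sapiens), read by scintillation counting, with a stated time of 2 h; a lower number here means a stronger inhibitor, a higher number a weaker inhibitor:
- compound 1 `Cn1nc(CN2CCCC2)nc1-c1ccc(C(C)(C)C)cc1`: 7.5 nM
- compound 2 `CC(C)(C)c1ccc(-c2nc(CN3CCCC3)nn2C2CC2)cc1`: 14 nM

Compound 2 holds the higher of the two numbers, but the step of a 1.9-fold higher number from compound 1 to compound 2 (0.27 log units; within the scatter) lies within the scatter, so the two compounds cannot be ordered on these data. Compound 3 `CC(C)n1nc(CN2CCCC2)nc1-c1ccc(C(C)(C)C)cc1` differs from compound 2 by isopropyl in place of cyclopropyl on an aromatic nitrogen. For the measured compounds named here, no measured step covers this exchange; the only step at the same aromatic nitrogen, a 1.9-fold higher number from compound 1 to compound 2 (0.27 log units; within the scatter), was small, which suggests that group size at this position matters little and that a 1.2-fold lower number from compound 2 to compound 3 (0.07 log units; within the scatter) should stay within the scatter. Compound 3 is therefore expected at 12 nM, with a range of 5 nM to 30 nM.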

Compound 3, inhibition constant: 2.2 nM
Estimate against measurement, compound 3: 5.5-fold (0.74 log units) above, and the stated range ends above it.
By their numbers in this assay, from the lowest: compound 3; then compounds 1 and 2 (each within the scatter of the next).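

In this assay, this aromatic nitrogen proves sensitive to the group it carries: a 6.4-fold lower number from compound 2 to compound 3 (0.80 log units; beyond the scatter) accompanies an exchange that keeps the count of heavy atoms and removes only the three-membered ring. Isopropyl also stands apart from methyl, with a 3.4-fold lower number from compound 1 to compound 3 (0.53 log units; beyond the scatter) while methyl and cyclopropyl could not be ordered. Nothing measured on these compounds explains the difference.

Still open, from the compounds shown here alone, is how the number moves with tert-butyl or a straight propyl chain on this nitrogen. It is also unknown whether isopropyl keeps its advantage when another amine replaces the pyrrolidine.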